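A few compounds are considered here, and "the series" means these few. Any claim that something is new, unique, unknown or untested is made for them only; others in the source may bear on it.

Measured compounds:
compound 1 `O=C(CCCCCCc1ccccc1)c1ncc(-c2ccccc2F)o1` — 110 nM
compound 2 `O=C(CCCCCCc1ccccc1)c1ncc(C(=O)C(F)(F)F)o1` — 4 nM

In an assay (Rattus norvegicus) for inhibition of Fatty-acid amide hydrolase 1 (Homo sapiens) (on this read-out higher numbers stand for weaker inhibition and lower numbers for stronger inhibition), compound 2 holds the lowest of the two numbers, with compound 1 the nearest at a step of a 28-fold lower number from compound 1 to compound 2 (1.44 log units; beyond the scatter). Compound 3 `CN1CCN(C(=O)c2cnc(C(=O)CCCCCCc3ccccc3)o2)CC1` is not yet measured. It differs from compound 2 by 4-methylpiperazin-1-yl in place of trifluoromethyl on a carbonyl carbon. Among the measured compounds shown here, only one measured step bears on this change: the step from compound 1 to compound 2, in which the (trifluoromethyl)carbonyl entered and gave a 28-fold lower number from compound 1 to compound 2 (1.44 log units; beyond the scatter), a large move. Compound 3 removes the trifluoromethyl from that very carbonyl, so the part that entered in the large step is taken away again. A step back in the other direction, beyond the scatter, is therefore expected, and the expected step for compound 3 is a 50-fold higher number from compound 2 to compound 3 (1.70 log units; beyond the scatter). Compound 3 is estimated at 200 nM, within a range of 30 nM to 2000 nM in this assay.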

Compound 3, inhibition constant: 80 nM
Estimate against measurement, compound 3: 2.5-fold (0.40 log units) above; the measured number falls inside the stated range.
By their numbers in this assay, from the lowest: compound 2; then compounds 3 and 1 (each within the scatter of the next).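

In this assay the carbonyl alone does not hold the low number: keeping it on the aromatic carbon while putting 4-methylpiperazin-1-yl in place of trifluoromethyl gives a 20-fold higher number from compound 2 to compound 3 (1.30 log units; beyond the scatter) on the same read-out. The (4-methylpiperazin-1-yl)carbonyl and the 2-fluorophenyl on the aromatic carbon cannot be told apart, with a 1.4-fold lower number from compound 1 to compound 3 (0.14 log units; within the scatter) between them. Among these three compounds, only the (trifluoromethyl)carbonyl stands apart at this position, and the earlier pair could not separate the carbonyl from the group it carries.

From the compounds shown here alone, whether a dimethylamine amide, a carboxylic acid or a methyl ester on this carbonyl carbon would read closer to compound 2 or to compound 3 stays open. Nothing given here offers an explanation for the step between compound 2 and compound 3.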